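The source may hold more compounds than are shown below. What is called first, only, known or untested is meant among the compounds shown, and "the series" means these compounds.

Compound 2 `COc1cccc(/C=C/C(=O)Nc2cc(C(=O)c3cc(OC)c(OC)c(OC)c3)cc(OC)c2OC)c1` gives 8700 nM in a functional assay on HT-29 cells (Homo sapiens) for cytotoxicity, read by MTT assay, with a stated time of 72 h (on this read-out lower numbers stand for stronger inhibition and higher numbers for weaker inhibition), the higher of the two numbers measured; compound 1 `COc1cc(C(=O)c2cc(OC)c(OC)c(OC)c2)cc(NC(=O)/C=C/c2cc(OC)c(OC)c(OC)c2)c1OC` gives 3100 nM. For the measured compounds named here, the one step seen so far, a 2.8-fold higher number from compound 1 to compound 2 (0.45 log units; beyond the scatter), shows that changing the aromatic ring on the double-bonded chain carbon shifts this read-out modestly. Compound 3 `COc1ccc(/C=C/C(=O)Nc2cc(C(=O)c3cc(OC)c(OC)c(OC)c3)cc(OC)c2OC)cc1N` takes that ring one way further: 3-amino-4-methoxyphenyl in place of 3-methoxyphenyl on a double-bonded chain carbon bound to a double-bonded chain carbon. Going by the values given here, no measured pair covers the entry of an amino group, so the expectation rests on compound 1 alone, whose richer ring gave 3100 nM. A modest move toward stronger inhibition is therefore expected for compound 3, estimated at 3000 nM (range 1000 nM to 9000 nM), meaning an expected step of a 2.9-fold lower number from compound 2 to compound 3 (0.46 log units; beyond the scatter).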

Compound 3, half-maximal inhibitory concentration: 7700 nM
The estimate for compound 3 lay 2.6-fold (0.41 log units) below the measured number, and the stated range covers the measured number.
By their numbers in this assay, from the lowest: compound 1; then compounds 3 and 2 (each within the scatter of the next).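

In this assay the exchange of 3-methoxyphenyl for 3-amino-4-methoxyphenyl gives a 1.1-fold lower number from compound 2 to compound 3 (0.05 log units; within the scatter) and so does not separate these two rings at this position. Set against 3,4,5-trimethoxyphenyl, the same 3-amino-4-methoxyphenyl ring gives a 2.5-fold higher number from compound 1 to compound 3 (0.40 log units; beyond the scatter) and so stays apart from it, as 3-methoxyphenyl did. No measurement at hand accounts for this result. The compounds shown leave open what a hydroxyl group or a fluorine atom would do in place of the amino group, and what number a plain phenyl ring would give here.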